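Benzyl amide series: from compound 3 to compound 4

This account rests on a few compounds, and the source may have more. Where it says the series, first, only, none or still open, it means among the compounds named here.

Measured so far in a functional assay on A2780 cells (Homo sapiens) for antiproliferative activity, read by resazurin assay, with a stated time of 72 h; on this read-out higher numbers stand for weaker inhibition and lower numbers for stronger inhibition
compound 1 `CN(Cc1ccccc1)C(=O)c1cc2c(Cc3ccccc3)n[nH]c2cc1O` gives 980 nM
compound 2 `CN(Cc1ccccc1Cl)C(=O)c1cc2c(Cc3ccccc3)n[nH]c2cc1O` gives 1100 nM
compound 3 `CCc1ccc(CN(C)C(=O)c2cc3c(Cc4ccccc4)n[nH]c3cc2O)cc1` gives 9400 nM

Compound 3 has the highest number of the three. Both steps leading to it are modest and beyond the scatter (a 9.6-fold higher number from compound 1 to compound 3 (0.98 log units; beyond the scatter)) (an 8.5-fold higher number from compound 2 to compound 3 (0.93 log units; beyond the scatter)). The remaining step lies within the scatter (a 1.1-fold higher number from compound 1 to compound 2 (0.05 log units; within the scatter)).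

The next structure is compound 4 `COc1cc(CN(C)C(=O)c2cc3c(Cc4ccccc4)n[nH]c3cc2O)ccc1Cl` and the change is on a saturated chain carbon bound to an amide-type nitrogen (4-chloro-3-methoxyphenyl in place of 4-ethylphenyl on a saturated chain carbon bound to an amide-type nitrogen). Going by the values given here, the ethyl group leaves, and among the measured steps its addition to compound 1 is the one that raised the number (a 9.6-fold higher number from compound 1 to compound 3 (0.98 log units; beyond the scatter)). The chloro group enters, and in compound 2 its addition gave no shift beyond the scatter (a 1.1-fold higher number from compound 1 to compound 2 (0.05 log units; within the scatter)). Among the compounds with values here, no measured compound carries a methoxy group, so that part of the change is untested.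

A modest fall in the number is therefore expected in this assay, with only a partial return towards compound 1 and compound 2. The expected change is a modest one (a 2.7-fold lower number from compound 3 to compound 4 (0.43 log units; beyond the scatter)). For compound 4 the estimated value is 3500 nM with an expected range from 1000 nM to 12000 nM (the upper end leaves room for no real change).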

Compound 4, half-maximal inhibitory concentration: 4100 nM
Estimate against measurement, compound 4: 1.2-fold (0.07 log units) below; low and high end bracket the measured number.
By their numbers in this assay, from the lowest: compounds 1 and 2 (each within the scatter of the next); then compound 4; then compound 3.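

In this assay, 4-chloro-3-methoxyphenyl in place of 4-ethylphenyl on the saturated chain carbon bound to the amide-type nitrogen gives a partial recovery (a 2.3-fold lower number from compound 3 to compound 4 (0.36 log units; beyond the scatter)), so the high number of compound 3 is not shared by every substituted phenyl at this position. The recovery is incomplete: the new group still stands apart from 2-chlorophenyl (a 3.7-fold higher number from compound 2 to compound 4 (0.57 log units; beyond the scatter)) and from the unsubstituted phenyl (a 4.2-fold higher number from compound 1 to compound 4 (0.62 log units; beyond the scatter)), so compound 4, like compound 3 and unlike compound 2, shows that a substituted ring here can carry a cost beyond the scatter. Nothing measured on these groups accounts for the size of these steps.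

The compounds shown do not divide the step between the chloro and the methoxy group, and with so few rings they do not settle whether the place of a substituent or its identity governs the number. Also open, going by these compounds, is how the number at this position responds to a longer chain in place of the ethyl group, or to an amine or a carboxylic acid on the ring.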